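Fluoro for chloro on two related indole cores

The compounds below may be only part of what the source reports. "The series", "measured", "known", "first", "only" and "open" are said of these compounds alone.

The series is followed in an ADME assay on microsomes from liver (Homo sapiens) for metabolic stability, using NADPH, with a stated time of 40 min, tested at 2 uM; a higher number here means that the compound lasts longer, a lower number that the compound disappears faster. Compound 1 `Fc1cc(Cl)c2[nH]cc(-c3ccc4ccccc4n3)c2c1` gives 0.383 h there. Compound 2 `Fc1cc(F)c2[nH]cc(-c3ccc4ccccc4n3)c2c1` differs from it by fluoro in place of chloro on an aromatic carbon, and in this assay compound 2 gives 0.45 h; the step of a 1.2-fold higher number from compound 1 to compound 2 (0.07 log units; within the scatter). Compound 3 `Fc1ccc2c(-c3ccc4ccccc4n3)c[nH]c2c1Cl` carries the same atoms as compound 1 joined differently; the difference between the two cores is not broken down here. In this assay compound 3 gives 0.183 h, the lowest of the three numbers, with compound 1 nearest and compound 2 furthest, both beyond the scatter.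

Compound 4 `Fc1ccc2c(-c3ccc4ccccc4n3)c[nH]c2c1F` is not yet measured. It differs from compound 3 by fluoro in place of chloro on an aromatic carbon. This is the same kind of change as from compound 1 to compound 2, but the place lines are not identical: in compound 3 the exchanged atom is ortho to a fluoro group, whereas in compound 1 it is meta to a fluoro group. Because a 1.2-fold higher number from compound 1 to compound 2 (0.07 log units; within the scatter) stayed within the scatter, the step from compound 3 to compound 4 is expected to be of similar size, a 1.2-fold higher number from compound 3 to compound 4 (0.08 log units; within the scatter). Compound 4 is therefore estimated at 0.22 h, expected between 0.12 h and 0.4 h.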

Compound 4, half-life: 0.167 h
Estimate against measurement, compound 4: 1.3-fold (0.12 log units) above; the measured number falls inside the stated range.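

On the core of compound 3, fluoro in place of chloro gives a 1.1-fold lower number from compound 3 to compound 4 (0.04 log units; within the scatter) in this assay, so this exchange produces no readable change in half-life on this core. For the compounds shown here, the exchange behaves alike on the two cores, with no difference between the steps that stands clear of the scatter: the same change on two cores in this assay, a 1.2-fold higher number (0.07 log units; within the scatter) from compound 1 to compound 2 and a 1.1-fold lower number (0.04 log units; within the scatter) from compound 3 to compound 4, 1.3-fold (0.11 log units) apart, within the scatter of two such steps. This supports treating the exchange as neutral for half-life on these two cores only; it rests on a single pair per core, says nothing about a third core or about other changes, and does not explain why compound 3 stands apart from compound 1.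

The compounds shown vary only chloro and fluoro at the exchanged place, so it remains open whether a methoxy, a nitrile or an amine there would move the number in this assay beyond the scatter. Also open, on these data alone, is whether groups of this kind would behave alike on both cores, as the two halogens do.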